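The source may hold more compounds than are shown below. What is called first, only, known or untested is meant among the compounds shown, and "the series" means these compounds.

In a functional assay on HL-60 cells (Homo sapiens) for cytotoxicity, read by MTT assay, with a stated time of 48 h (on this read-out higher numbers stand for weaker inhibition and lower numbers for stronger inhibition), compound 1 `[O-][n+]1nc(NCc2ccccc2Cl)[n+]([O-])c2ccccc21` gives 5800 nM and compound 2 `[O-][n+]1nc(NCCO)[n+]([O-])c2ccccc21` gives 10700 nM. The gap between them is a 1.8-fold higher number from compound 1 to compound 2 (0.27 log units; within the scatter), so these two quite different chains on the amino nitrogen read alike here. Compound 3 `CCN(CC)c1n[n+]([O-])c2ccccc2[n+]1[O-]` reads > 49000 nM, which is a limit of the assay and not a number. It stands at the limit of > 49000 nM in this assay, at which 1 of the 3 values shown sits. Compound 4 `C=CCNc1n[n+]([O-])c2ccccc2[n+]1[O-]` has allylamino in place of diethylamino on an aromatic carbon, the same core otherwise (allylamino in place of diethylamino on an aromatic carbon). The closest measured step is an at least 4.5-fold higher number from compound 2 to compound 3 (0.66 log units; beyond the scatter), and the new change runs the opposite way, from diethylamino back to an amino group that keeps a hydrogen-bond donor, as the group in compound 2 does. A return towards the level of compound 2, at 10700 nM, therefore seems likely, though this rests on very few compounds. The expected result is an at least 6.1-fold lower number from compound 3 to compound 4 (0.78 log units; beyond the scatter), a move towards stronger inhibition. For compound 4 the estimated value is 8000 nM, with an expected range from 3000 nM to 25000 nM.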

Compound 4, half-maximal inhibitory concentration: 25800 nM
Compound 4: the middle estimate sits 3.2-fold (0.51 log units) below what was measured; measured number outside the range, above it.
By their numbers in this assay, from the lowest: compounds 1 and 2 (each within the scatter of the next); then compound 4. At a limit, above all of these: compound 3.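

In this assay, an allylamino group on this aromatic carbon keeps a hydrogen on its nitrogen, as the chains of the two earlier amines do, yet the level of those amines does not return: the steps read a 2.4-fold higher number from compound 2 to compound 4 (0.38 log units; beyond the scatter) and a 4.4-fold higher number from compound 1 to compound 4 (0.65 log units; beyond the scatter). Among these three amines the choice of chain on the nitrogen can therefore move the number beyond the scatter, which the earlier pair alone did not show. The remaining step, an at least 1.8-fold lower number from compound 3 to compound 4 (0.27 log units; that floor lies within the scatter), is only a floor, as its starting point is a limit of the assay and not a number: the limit of > 49000 nM in this assay, at which 1 of the 4 values shown sits.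

As far as these compounds go, how far allylamino truly stands from diethylamino stays open. A saturated propylamino chain would show whether the double bond counts here, and a benzylamino group would show the same for the chlorine.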